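The compounds below may be only part of what the source reports. "The series", "measured", "known", "first", "only" and "open" are said of these compounds alone.

Working notes on the series. Compound 1 `COc1ccc(CNc2nc3cc(N)cc(N)c3nc2-c2ccccc2)cc1OC` gives 6310 nM in a functional assay on NCI-H522 cells (Homo sapiens) for inhibition, read by sulforhodamine B assay, with a stated time of 48 h; on this read-out lower numbers stand for stronger inhibition of growth and higher numbers for weaker inhibition of growth. Compound 3 `COc1ccc(CNc2nc3cc(N)cc(N)c3nc2-c2ccccc2)cc1` gives 21900 nM in this assay; the step of a 3.5-fold higher number from compound 1 to compound 3 (0.54 log units; beyond the scatter) corresponds to hydrogen in place of methoxy on an aromatic carbon. Compound 2 `Nc1cc(N)c2nc(-c3ccccc3)c(NCc3ccc(F)cc3)nc2c1` gives only a limit of the assay in this assay, < 100000 nM, so among the numbers shown its standing cannot be fixed (the limit of < 100000 nM in this assay, at which 1 of the 3 values shown sits). The steps a step that the limit leaves unreadable from compound 1 to compound 2 and a step that the limit leaves unreadable from compound 2 to compound 3 are therefore unreadable as well.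

Compound 4 `Nc1cc(N)c2nc(-c3ccccc3)c(Sc3ccc(F)cc3)nc2c1` has not yet been measured. It differs from compound 2 by (4-fluorophenyl)sulfanyl in place of (4-fluorobenzyl)amino on an aromatic carbon. Among the measured compounds shown here, no measured step bears on this change: the only readable step, a 3.5-fold higher number from compound 1 to compound 3 (0.54 log units; beyond the scatter), concerns a methoxy group and not the exchange made here, and both steps into compound 2 are hidden by its limit. Any expectation in this assay therefore rests on the limit alone and has no direction to lean on. Compound 4 is estimated at 30000 nM, with a range from 6000 nM to 100000 nM. The step that the limit leaves unreadable from compound 2 to compound 4 is accordingly expected only as a rough placing, with a fair chance that the assay again reports no more than a limit.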

Compound 4, concentration for total growth inhibition: < 100000 nM
Compound 4: a limit, no number; the forecaster's own chance of this, stated with the estimate: 40%; the middle value lies beyond the limit too.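

Among the compounds shown here, compound 2 and compound 4 both sit at a limit of the assay in this assay, so no step between them can be read: the limit of < 100000 nM in this assay, at which 2 of the 4 values shown sit. Left open is whether, in this assay and short of that limit, (4-fluorophenyl)sulfanyl and (4-fluorobenzyl)amino differ at all.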